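This account rests on a few compounds, and the source may have more. Where it says the series, first, only, none or still open, it means among the compounds named here.

Of the compounds shown here, three in this set have been measured. Compound 1 `CCCCCCCCCCn1cc(-c2nc3ccccc3cc2C)nn1` gives 28.2 ug/mL in a functional assay on HeLa cells (Homo sapiens) for cytotoxicity, read by MTT assay, with a stated time of 24 h; a higher number here means a weaker inhibitor, a lower number a stronger inhibitor. Compound 2 `Cc1cc2ccccc2nc1-c1cn(CCC(F)(F)C(F)(F)C(F)(F)C(F)(F)C(F)(F)C(F)(F)C(F)(F)C(F)(F)F)nn1` reaches only the limit of this assay, reported as > 100 ug/mL. Compound 3 `CCCc1cc2ccccc2nc1-c1cn(-c2ccc(F)cc2)nn1` likewise stops at the limit, reported as > 100 ug/mL. Compound 2 therefore stands with compound 3 at the limit of > 100 ug/mL in this assay, at which 2 of the 3 values shown sit, while compound 1 alone returns a number.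

Compound 4 `CCCc1cc2ccccc2nc1-c1cn(CCC(F)(F)C(F)(F)C(F)(F)C(F)(F)C(F)(F)C(F)(F)C(F)(F)C(F)(F)F)nn1` has not yet been measured. It differs from compound 2 by ethyl in place of hydrogen on a saturated chain carbon bound to an aromatic carbon; cut one bond further out, the same change reads methyl to propyl. For the measured compounds named here, no pair of measured compounds differs in exactly this one place, so no measured step can be pointed to. Compound 3 carries the propyl group and sits at the limit, and compound 2 sits at the limit as well, so no movement beyond the scatter is expected.

The step from compound 2 to compound 4 is estimated at a step that the limit leaves unreadable from compound 2 to compound 4. Compound 4 is therefore expected to give about 150 ug/mL, within a range from 60 ug/mL to 400 ug/mL, and most likely to be reported again only as a limit.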

Compound 4, half-maximal inhibitory concentration: 37.8 ug/mL
Beside the measured number, compound 4's estimate is 4.0-fold (0.60 log units) above it; measured number below the stated range.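

In this assay, ethyl in place of hydrogen on a saturated chain carbon bound to an aromatic carbon gives an at least 2.6-fold lower number from compound 2 to compound 4 (0.42 log units; beyond the scatter), so this position can change the reading when the rest of the structure stays the same. Compound 3, which also carries the propyl group, remains at a limit, > 100 ug/mL, so propyl does not bring a readable number in every compound shown. The step can be given only as a lower bound, because compound 2 has no exact value: the limit of > 100 ug/mL in this assay, at which 2 of the 4 values shown sit.

Going by these compounds, whether a longer chain or an amine at this position would lower the number further remains open. On these data alone, it is also open how large the change from methyl to propyl would be between two compounds that both give exact values.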